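A Bulkier Amine Substituent on the Shared Core

The source may hold more compounds than are shown below. What is called first, only, known or untested is meant among the compounds shown, and "the series" means these compounds.

Compound 3 `COC(=O)CNCCCOc1ccc2cc(NC(=O)c3ccc(O)c(CC=C(C)C)c3)c(=O)oc2c1C` gives 1060 nM in a functional assay on SK-BR-3 cells (Homo sapiens) for antiproliferative activity (on this read-out lower numbers stand for stronger inhibition and higher numbers for weaker inhibition), the higher of the two numbers seen. Compound 1 `CC(C)=CCc1cc(C(=O)Nc2cc3ccc(OCC4CCCNC4)c(C)c3oc2=O)ccc1O` gives 600 nM, and a 1.8-fold higher number from compound 1 to compound 3 (0.25 log units; within the scatter). Compound 2 `CCCN(CCC)CCCOc1ccc2cc(NC(=O)c3ccc(O)c(CC=C(C)C)c3)c(=O)oc2c1C` reaches only the limit of the assay, > 50000 nM. Compound 4 `CC(C)=CCc1cc(C(=O)Nc2cc3ccc(OCCCN[C@H](C)c4ccccc4)c(C)c3oc2=O)ccc1O` differs from compound 3 by 1-phenylethyl in place of (methoxycarbonyl)methyl on an amine nitrogen. For the measured compounds named here, two measured steps bear on this same nitrogen: an at least 83-fold higher number from compound 1 to compound 2 (1.92 log units; beyond the scatter) and an at least 47-fold lower number from compound 2 to compound 3 (1.67 log units; beyond the scatter). Both show that enlarging the groups on this amine can push the number far upward, and 1-phenylethyl is again a larger group than (methoxycarbonyl)methyl, so a rise is expected for compound 4, though a smaller one than the step to the dipropylamino of compound 2 because an at least 47-fold lower number from compound 2 to compound 3 (1.67 log units; beyond the scatter) involved two chains entering at once. Compound 4 is therefore expected at 3000 nM, within 800 nM to 15000 nM, which means a 2.8-fold higher number from compound 3 to compound 4 (0.45 log units; beyond the scatter).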

Compound 4, half-maximal inhibitory concentration: 1000 nM
Beside the measured number, compound 4's estimate is 3.0-fold (0.48 log units) above it; measured number inside the range.
By their numbers in this assay, from the lowest: compounds 1, 4 and 3 (each within the scatter of the next). At a limit, above all of these: compound 2.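

Size alone does not set the number on this amine nitrogen: 1-phenylethyl in place of (methoxycarbonyl)methyl gives a 1.1-fold lower number from compound 3 to compound 4 (0.03 log units; within the scatter), and 2-((1-phenylethyl)amino)ethyl in place of piperidin-3-yl gives a 1.7-fold higher number from compound 1 to compound 4 (0.22 log units; within the scatter). Dipropylamino stands apart from the (1-phenylethyl)amino group, with an at least 50-fold lower number from compound 2 to compound 4 (1.69 log units; beyond the scatter), so one large group on this nitrogen keeps the number in the range of compound 1, whereas two propyl chains do not. That step rests on a limit of the assay for compound 2: the limit of > 50000 nM in this assay, at which 1 of the 4 values shown sits.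

Going by these compounds, it stays open whether a single propyl chain or a benzyl group on this nitrogen would behave like compound 4 or like compound 2. The mirror-image form of the 1-phenylethyl group also remains an open question.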